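Replacing the benzothiazolyl amide with a dimethoxybenzyl amide

A few compounds are considered here, and "the series" means these few. Any claim that something is new, unique, unknown or untested is made for them only; others in the source may bear on it.

Measured compounds:
- compound 1, `Cc1ccc(O)c(C(O)(C(F)(F)F)C(F)(F)F)c1`: 207000 nM
- compound 2, `Oc1cc(-c2ccccc2)ccc1C(O)(C(F)(F)F)C(F)(F)F`: a limit, > 500000 nM
- compound 3, `O=C(COc1ccc2cc(C(O)(C(F)(F)F)C(F)(F)F)c(O)cc2c1)Nc1nc2ccccc2s1`: 10900 nM

All three share a phenol bearing a hexafluoro-hydroxyisopropyl group and were tested in an assay on isolated protein for inhibition of receptor-type tyrosine-protein phosphatase C (Homo sapiens), read by spectrophotometry; on this read-out higher numbers stand for weaker inhibition and lower numbers for stronger inhibition. Compound 1 gives 207000 nM. For compound 2 the read-out stops at a limit of the assay, > 500000 nM, so only a limit and no number is known, as noted in the limit of > 500000 nM in this assay, at which 1 of the 3 values shown sits. Compound 3 gives 10900 nM, the lowest of the two numbers; compound 1 sits a clearly higher number away, beyond the scatter.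

Compound 4, `COc1ccc(CNC(=O)COc2ccc3cc(C(O)(C(F)(F)F)C(F)(F)F)c(O)cc3c2)cc1OC`, has not been measured. It differs from compound 3 in one place: 3,4-dimethoxybenzyl in place of 1,3-benzothiazol-2-yl on an amide-type nitrogen. Both groups carry two hydrogen-bond acceptors and no donor, so the change keeps the amide and its acceptor count while swapping a fused heteroaromatic ring for a methylene-linked dimethoxyphenyl ring. Going by the values given here, no measured pair shows this change, so its effect is uncertain. The step from compound 3 to compound 4 is expected to be small, a 1.5-fold higher number from compound 3 to compound 4 (0.17 log units; within the scatter), within or near the scatter and, if anything, toward a weaker number. Compound 4 is therefore expected to give about 16000 nM, with a plausible range from 5000 nM to 60000 nM.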

Compound 4, half-maximal inhibitory concentration: > 20000 nM
Compound 4: only a limit was reported (the forecaster's own chance of this, stated with the estimate: 10%); at least 1.2-fold (0.09 log units) between middle value and limit.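

Set against compound 3 in this assay, placing 3,4-dimethoxybenzyl in place of 1,3-benzothiazol-2-yl on the amide-type nitrogen gives an at least 1.8-fold higher number from compound 3 to compound 4 (0.26 log units; that floor lies within the scatter). Going by these compounds, compound 4 therefore has no number in this assay, only a limit: the limit of > 20000 nM in this assay, at which 1 of the 4 values shown sits. This first look at the group on this nitrogen shows no gain in inhibition from the change, but the size of any loss stays unknown, and the floor alone does not separate the two compounds beyond the scatter.

The compounds shown leave open where compound 4 truly lies and whether the outcome follows from losing 1,3-benzothiazol-2-yl or from the methylene link that 3,4-dimethoxybenzyl brings. They also leave open what an unsubstituted benzyl or phenyl group, or a chain ending in a carboxylic acid, would give on this nitrogen.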